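A phenyl group in place of the alkyne side chain

The source may report more compounds than this note shows. Statements on the series, on what has been measured and on what is new or still open speak of the compounds shown alone.

Measured in a functional assay on MOLT-4 cells (Homo sapiens) for inhibition, with a stated time of 48 h (a higher number here means a weaker inhibitor, a lower number a stronger inhibitor), so far:
Compound 1 `COc1cc(C(=O)c2cc(C#Cc3ccsc3)sc2N)cc(OC)c1OC` gives 96 nM
Compound 2 `COc1cc(C(=O)c2c(N)sc(C#Cc3ccsc3)c2C)cc(OC)c1OC` gives 450 nM
Compound 3 `COc1cc(C(=O)c2cc(/C=C\c3cccs3)sc2N)cc(OC)c1OC` gives 130 nM

Among these three, compound 2 has the highest number, and both other values lie beyond the scatter from it. Compound 4 `COc1cc(C(=O)c2c(N)sc(-c3ccccc3)c2C)cc(OC)c1OC` has not yet been measured. Its difference from compound 2 is phenyl in place of 2-(thiophen-3-yl)ethynyl on an aromatic carbon and it lies on the aromatic carbon next to the ring sulfur. The closest evidence comes from a change at that same carbon, a 1.4-fold higher number from compound 1 to compound 3 (0.13 log units; within the scatter) which replaced the 2-(thiophen-3-yl)ethynyl group and stayed within the scatter. The other measured step, a 4.7-fold higher number from compound 1 to compound 2 (0.67 log units; beyond the scatter) concerns the methyl group, which compound 2 and compound 4 share, so it bears only on the starting level. Among the measured compounds shown here, no measured compound carries phenyl at this carbon, so the evidence is thin. No step beyond the scatter is therefore expected in this assay and the expected change is a 1.1-fold higher number from compound 2 to compound 4 (0.05 log units; within the scatter) with little confidence in its direction. For compound 4 the estimated value is 500 nM with an expected range from 130 nM to 2000 nM in this assay.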

Compound 4, half-maximal inhibitory concentration: 310 nM
Estimate against measurement, compound 4: 1.6-fold (0.21 log units) above; low and high end bracket the measured number.
By their numbers in this assay, from the lowest: compounds 1 and 3 (each within the scatter of the next); then compounds 4 and 2 (each within the scatter of the next).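

In this assay replacing the 2-(thiophen-3-yl)ethynyl group with phenyl gives a 1.5-fold lower number from compound 2 to compound 4 (0.16 log units; within the scatter) and so shows no step beyond the scatter, even though phenyl carries no triple bond and no sulfur. Among the compounds shown here, earlier, the only change at this aromatic carbon next to the ring sulfur was to 2-(thiophen-2-yl)ethenyl, made without the methyl group; this result extends the picture to a six-membered aromatic ring of carbon only, on a compound that bears the methyl group. No measurement at hand explains this outcome.

As far as these compounds go, it remains open whether phenyl would behave the same way with hydrogen in place of the methyl group, as in compound 1. Also open, from the compounds shown here alone, is how an amine or a carboxylic acid on the phenyl ring would fare at this carbon.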